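Hydroxy to methoxy on the chlorophenyl ring of compound 1

A few compounds are considered here, and "the series" means these few. Any claim that something is new, unique, unknown or untested is made for them only; others in the source may bear on it.

Measured so far in a functional assay on UACC-62 cells (Homo sapiens) for inhibition, read by sulforhodamine B assay, with a stated time of 48 h, tested at 1 uM; a lower number here means a stronger effect, a higher number a weaker effect of the compound at the concentration tested:
compound 1 `O=C(Nc1cccc(-n2cc(-c3ccncc3)c(-c3cc(O)cc(Cl)c3)n2)c1)Nc1ccc(Cl)c(C(F)(F)F)c1`: 99%
compound 2 `O=C(Nc1cccc(-n2cc(-c3ccncc3)c(-c3cc(O)cc(Cl)c3)n2)c1)Nc1ccc(Cl)c(Cl)c1`: 83%

Among the measured compounds shown here, compound 1 holds the higher of the two numbers in this assay; compound 2 stands at 83%, and the only measured step, a number 16 percentage points lower from compound 1 to compound 2 (beyond the scatter), is a chloro in place of trifluoromethyl on an aromatic carbon.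

Compound 3 `COc1cc(Cl)cc(-c2nn(-c3cccc(NC(=O)Nc4ccc(Cl)c(C(F)(F)F)c4)c3)cc2-c2ccncc2)c1` differs from compound 1 by methyl in place of hydrogen on an oxygen on an aromatic ring, that is hydroxy to methoxy, 3-chloro-5-hydroxyphenyl to 3-chloro-5-methoxyphenyl. For the measured compounds named here, no measured step touches that oxygen; the step from compound 1 to compound 2 sits on a different ring and gives no guide to the size of this change. With nothing measured on it, the expected step is a number 9 percentage points lower from compound 1 to compound 3 (within the scatter), most likely within the scatter, with some allowance for a loss. Compound 3 is therefore estimated at 90%, in the range 70% to 100%.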

Compound 3, a percentage reported as activity, at one concentration (the size of the read-out at that concentration, not a potency): 82%
The estimate for compound 3 lay 8 percentage points above the measured number, within the range that was stated.
By their numbers in this assay, from the lowest: compounds 3 and 2 (each within the scatter of the next); then compound 1.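

In this assay, hydroxy to methoxy gives a number 17 percentage points lower from compound 1 to compound 3 (beyond the scatter), and a lower number here means a stronger effect at the concentration tested. The hydrogen on this oxygen is therefore not needed for the effect in the background of compound 1, and capping it with methyl strengthens the read-out rather than costing activity. This oxygen on the chlorophenyl ring is thus a second place in the series where a single change moves the number beyond the scatter, alongside the chloro for trifluoromethyl change on the other aryl ring. Nothing available explains why methyl at this oxygen acts this way.

On these data alone, it remains open whether the same change holds with the chloro in place of trifluoromethyl, as in compound 2. Also open, as far as these compounds go, is how an ethoxy group or an amine in place of the methoxy would read.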